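Moving a Trifluoromethyl Group in a Calcium Channel Series

The source may report more compounds than this note shows. Statements on the series, on what has been measured and on what is new or still open speak of the compounds shown alone.

Compound 1, `CN(Cc1ccc(OCCCN)cc1)c1nc2ccc(Oc3ccccc3)cc2s1`, gives 49000 nM in an assay on SH-SY5Y cells for inhibition of Voltage-dependent N-type calcium channel subunit alpha-1B (Homo sapiens), read by FLIPR and calcium flux, with stated times of 600 s and 300 s, in the presence of a further agent that is not named here; on this read-out lower numbers stand for stronger inhibition and higher numbers for weaker inhibition.
Compound 2, `CN(Cc1ccc(OCCCN)cc1)c1nc2ccc(Oc3ccc(C(F)(F)F)cc3)cc2s1`, gives 283000 nM in this assay.
Compound 3, `CN(Cc1ccc(OCCCNC(=N)N)cc1)c1nc2ccc(Oc3ccccc3)cc2s1`, gives 113000 nM in this assay.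

Compound 3 differs from compound 1 in its core by a group of 3 heavy atoms (1 carbon, 2 nitrogen; no ring) in place of a hydrogen atom, on an amine nitrogen, and this produced a 2.3-fold higher number from compound 1 to compound 3 (0.36 log units; beyond the scatter). Compound 2 differs from compound 1 by trifluoromethyl in place of hydrogen on an aromatic carbon, a change that produced a 5.8-fold higher number from compound 1 to compound 2 (0.76 log units; beyond the scatter). Compound 4, `CN(Cc1ccc(OCCCNC(=N)N)cc1)c1nc2ccc(Oc3cccc(C(F)(F)F)c3)cc2s1`, has not yet been measured; it differs from compound 3 by trifluoromethyl in place of hydrogen on an aromatic carbon. The surroundings of the change are not identical: in compound 2 the entering group is para to a large group, whereas in compound 4 it is meta to a large group, so this is the same kind of change rather than the same change. Compound 4 is therefore expected to show a weakening step of a 4.0-fold higher number from compound 3 to compound 4 (0.60 log units; beyond the scatter), resting on the earlier step of a 5.8-fold higher number from compound 1 to compound 2 (0.76 log units; beyond the scatter) in this assay and on the value of compound 3, 113000 nM. On this basis compound 4 is estimated at 450000 nM, within a range from 150000 nM to 1400000 nM.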

Compound 4, half-maximal inhibitory concentration: 202000 nM
Compound 4: the middle estimate sits 2.2-fold (0.35 log units) above what was measured; measured number inside the range.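

On the core of compound 3, the trifluoromethyl change gave a 1.8-fold higher number from compound 3 to compound 4 (0.25 log units; within the scatter) in this assay, so the clear loss seen on the core of compound 1 did not carry over at its earlier size. Set side by side, the two steps differ by more than repeated measurements would explain: the same change on two cores in this assay, a 5.8-fold higher number (0.76 log units; beyond the scatter) from compound 1 to compound 2 and a 1.8-fold higher number (0.25 log units; within the scatter) from compound 3 to compound 4, 3.2-fold (0.51 log units) apart, beyond the scatter of two such steps. This does not show that the core alone separates them: in compound 4 the group stands meta to a large group and in compound 2 at another place on that ring, so core and place change together, and each step rests on a single pair.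

The compounds shown leave open how 3-(trifluoromethyl)phenoxy would behave on the core of compound 1, and how the group would behave on the core of compound 3 at the place it holds in compound 2, comparisons that would separate core from place. Also open, as far as these compounds go, is whether a chlorine atom or a nitrile in place of trifluoromethyl would follow the same course on the two cores.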